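Trimming a Hydroxy-Azido Arm to Methyl on the Shared Core

The source may report more compounds than this note shows. Statements on the series, on what has been measured and on what is new or still open speak of the compounds shown alone.

Measured compounds:
compound 1, `C=CCn1c(=S)n(C2OC(COCc3ccccc3)[C@H]3OC(C)(C)O[C@@H]23)c2nc(N)nc(O)c21`, 77%
compound 2, `[N-]=[N+]=NCC(O)Cn1c(=O)n(C2OC(CO)[C@@H](O)[C@H]2O)c2nc(N)nc(O)c21`, 91%
compound 3, `C=CCn1c(=O)n(CCCCCCCC)c2nc(N)nc(O)c21`, 130%

In a functional assay on the whole organism (B cells) with Mus musculus as the target (on this read-out lower numbers stand for smaller maximal responses and higher numbers for larger maximal responses), compound 2 holds the second highest of the three numbers. Its nearest neighbour is compound 1, whose value lies lower by a gap beyond the usual scatter; compound 3 lies furthest away, higher by a gap also beyond the scatter. Compound 4, `CCn1c(=O)n(C2OC(CO)[C@@H](O)[C@H]2O)c2nc(N)nc(O)c21`, is not yet measured. It differs from compound 2 in one place: methyl in place of 2-azido-1-hydroxyethyl on a saturated chain carbon bound to an aromatic nitrogen. Within the data shown here, no pair of measured compounds differs in a single place, so nothing measured here shows how such a change moves this assay. The expected step from compound 2 to compound 4 is therefore small, a number 1 percentage points lower from compound 2 to compound 4 (within the scatter), with no clear direction beyond the scatter. For compound 4 the estimate is 90%, ranging from 68% to 115%.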

Compound 4, largest response reached (reported as maximal response), in percent of the reference or control that the assay uses: 82%
The estimate for compound 4 lay 8 percentage points above the measured number; the measured number falls inside the stated range.
By their numbers in this assay, from the lowest: compounds 1, 4 and 2 (each within the scatter of the next, the first and the last beyond it); then compound 3.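

Among these compounds, this is the first step in this assay that changes a single place: methyl in place of 2-azido-1-hydroxyethyl on a saturated chain carbon bound to an aromatic nitrogen gives a number 9 percentage points lower from compound 2 to compound 4 (within the scatter) and so stays within the usual scatter. On this shared core, then, a much smaller group at this place leaves the maximal response without a clear shift.

As far as these compounds go, whether an amine, a carboxylic acid or a longer chain at this place would move the response remains open. No available evidence explains this result.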